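Two Four-Membered Rings in Place of One Three-Membered Ring

This account rests on a few compounds, and the source may have more. Where it says the series, first, only, none or still open, it means among the compounds named here.

Compound 1 `CC(C)(C)c1ccc(C(=O)NCc2ccc(NS(=O)(=O)C3CC3)cc2Cl)cc1` gives 1500 nM in an assay on HeLa cells for agonist activity at Bile acid receptor (Homo sapiens), read by a luciferase reporter, with a stated time of 24 h; a higher number here means that more compound is needed for the effect, a lower number that less compound is needed.
Compound 2 `CS(=O)(=O)Nc1ccc(CNC(=O)c2ccc(C3(C(F)(F)F)CC3)cc2)c(Cl)c1` gives 540 nM in this assay .

Of the two compounds measured, compound 2 has the lower number, and its gap to compound 1 lies beyond the usual scatter, so less of compound 2 is needed for the effect. Compound 3 `CS(=O)(=O)Nc1ccc(CNC(=O)c2ccc(C34CC(C3)C4)cc2)c(Cl)c1` has not been measured yet. It keeps the whole of compound 2 except at one position: a group of 5 heavy atoms (5 carbon; 2 four-membered non-aromatic rings of carbon only) in place of a group of 7 heavy atoms (4 carbon, 3 fluorine; one three-membered non-aromatic ring of carbon only), on an aromatic carbon. Both groups are small, carry no hydrogen-bond donors or acceptors and sit at the same place on the ring, so the change is a modest one. Going by the values given here, no comparable pair of measured compounds is available to show how such a swap plays out here, so the expectation rests on the values of compound 1 and compound 2 alone. For compound 3 the expected step of a 1.5-fold higher number from compound 2 to compound 3 (0.17 log units; within the scatter) is small, with a slight lean toward a higher number, and the estimated value is 800 nM, with a likely range from 300 nM to 2500 nM.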

Compound 3, half-maximal effective concentration: 560 nM
Compound 3: the middle estimate sits 1.4-fold (0.15 log units) above what was measured; measured number inside the range.
By their numbers in this assay, from the lowest: compounds 2 and 3 (each within the scatter of the next); then compound 1.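

Replacing the 1-(trifluoromethyl)cyclopropyl group with the carbon-only group of two four-membered rings gives a 1.0-fold higher number from compound 2 to compound 3 (0.02 log units; within the scatter) in this assay, so the two compounds cannot be told apart. At this position on the aromatic ring, para to a large group, a group with no fluorine therefore does as well as one with fluorine, and a three-membered ring is not required, at least in this one pair. No measurement at hand explains why these two different groups give matching numbers.

On these data alone, it remains open whether this position would accept a group containing an amine or a carboxylic acid, or a longer chain such as a hexyl group. Also open, as far as these compounds go, is whether the match between these two groups would hold if another part of the molecule changed.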